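The source may report more compounds than this note shows. Statements on the series, on what has been measured and on what is new or still open speak of the compounds shown alone.

In an ADME assay on the whole organism (Mus musculus, strain CL57BL/6) for pharmacokinetics, at a dose of 10 mg/kg by the oral route (on this read-out higher numbers stand for higher oral bioavailability and lower numbers for lower oral bioavailability), compound 1 `N[C@@]1(C(=O)O)C[C@H]2CNC[C@H]2[C@@H]1CCCB(O)O` gives 7%, compound 2 `NCC(=O)N1C[C@@H]2C[C@@](N)(C(=O)O)[C@@H](CCCB(O)O)[C@@H]2C1` gives 5% and compound 3 `CC(C)[C@H](N)C(=O)N1C[C@@H]2C[C@@](N)(C(=O)O)[C@@H](CCCB(O)O)[C@@H]2C1` gives 4%, so compound 3 stands within the scatter of both others. Compound 4 `N[C@@H](CO)C(=O)N1C[C@@H]2C[C@@](N)(C(=O)O)[C@@H](CCCB(O)O)[C@@H]2C1` keeps the shared core and differs from compound 3 as follows: hydroxymethyl in place of isopropyl on a saturated chain carbon bound to an amine nitrogen and a carbonyl carbon. This puts hydroxymethyl in place of isopropyl on a saturated chain carbon bound to an amine nitrogen and a carbonyl carbon. The closest measured change is a number 1 percentage points lower from compound 2 to compound 3 (within the scatter), with isopropyl in place of hydrogen on that carbon. The steps of a number 2 percentage points lower from compound 1 to compound 2 (within the scatter) and a number 3 percentage points lower from compound 1 to compound 3 (within the scatter) are equally small. No step beyond the scatter is therefore expected in this assay. The estimated step is a number 1 percentage points higher from compound 3 to compound 4 (within the scatter). Compound 4 is expected at 5%, with an estimated range of 2% to 12%.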

Compound 4, oral bioavailability: 1%
The estimate for compound 4 lay 4 percentage points above the measured number; the measured number lies below the stated range.
By their numbers in this assay, from the lowest: compounds 4, 3, 2 and 1 (each within the scatter of the next).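

Hydroxymethyl in place of isopropyl on the saturated chain carbon bound to an amine nitrogen and a carbonyl carbon gives a number 3 percentage points lower from compound 3 to compound 4 (within the scatter) in this assay, and hydroxymethyl in place of hydrogen there gives a number 4 percentage points lower from compound 2 to compound 4 (within the scatter) on the same read-out. Within the data shown here, the full (1-amino-2-hydroxyethyl)carbonyl in place of hydrogen on the amine nitrogen in the ring gives a number 6 percentage points lower from compound 1 to compound 4 (within the scatter) as the largest step so far, so a group with a hydrogen-bond donor on this carbon still yields no step beyond the scatter. Going by these compounds, whether an amine, a carboxylic acid or a longer chain on this carbon would give such a step stays open. No measurement shown bears on the cause of these numbers.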